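The compounds below may be only part of what the source reports. "The series", "measured", "known", "first", "only" and "open" are said of these compounds alone.

Measured compounds:

Compound 1 `CNC(=O)Nc1c(C)c(C(OC(C)(C)C)C(=O)O)c(-c2ccc(C)c(C)c2)c(C)c1-c1ccc(C)c(C)c1`: 20000 nM
Compound 2 `Cc1ccc(-c2c(C)c(-c3ccc(C)c(C)c3)c(C(OC(C)(C)C)C(=O)O)c(C)c2NS(=O)(=O)c2ccccc2)cc1C`: 11000 nM
Compound 3 `CNc1c(C)c(C(OC(C)(C)C)C(=O)O)c(-c2ccc(C)c(C)c2)c(C)c1-c1ccc(C)c(C)c1`: 8800 nM

In an ADME assay on MT4 cells (Homo sapiens) for cytotoxicity, read by MTT assay, with a stated time of 4 days (a higher number here means that more compound is tolerated, a lower number that less compound is tolerated), compound 3 gives the lowest number of the three; compound 2 sits within the scatter of it, and only compound 1 lies beyond it, as a 2.3-fold lower number from compound 1 to compound 3 (0.36 log units; beyond the scatter) shows. Compound 4 `CCNC(=O)Nc1c(C)c(C(OC(C)(C)C)C(=O)O)c(-c2ccc(C)c(C)c2)c(C)c1-c1ccc(C)c(C)c1` differs from compound 3 in one place: ethylcarbamoyl in place of methyl on a nitrogen on an aromatic ring. Among the measured compounds shown here, the only measured step that bears on this change is a 2.3-fold lower number from compound 1 to compound 3 (0.36 log units; beyond the scatter), where a carbamoyl group on that nitrogen went with a modestly higher number than methyl. Reversing that direction, a modest rise in this assay is expected, roughly back to the level of compound 1. The expected step is a 2.0-fold higher number from compound 3 to compound 4 (0.31 log units; beyond the scatter). For compound 4 the estimate is 18000 nM, with a range from 9000 nM to 40000 nM.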

Compound 4, half-maximal cytotoxic concentration: 15000 nM
The estimate for compound 4 lay 1.2-fold (0.08 log units) above the measured number, within the range that was stated.
By their numbers in this assay, from the lowest: compounds 3, 2, 4 and 1 (each within the scatter of the next, the first and the last beyond it).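

In this assay, ethylcarbamoyl on the nitrogen gives a 1.7-fold higher number from compound 3 to compound 4 (0.23 log units; within the scatter), so unlike the methylcarbamoyl of compound 1, this carbamoyl group does not clear the scatter against methyl. Extending that group, with methyl in place of hydrogen on its chain, gives a 1.3-fold lower number from compound 1 to compound 4 (0.12 log units; within the scatter), and ethylcarbamoyl in place of phenylsulfonyl gives a 1.4-fold higher number from compound 2 to compound 4 (0.13 log units; within the scatter); neither step separates the compounds beyond the scatter. Nothing available offers a reason for these small differences. As far as these compounds go, whether a longer chain such as butylcarbamoyl, or an acetyl group, on that nitrogen would shift the number beyond the scatter remains open.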